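Methylsulfanyl in place of methylsulfonyl: notes on compound 3

This account rests on a few compounds, and the source may have more. Where it says the series, first, only, none or still open, it means among the compounds named here.

Measured so far:
compound 1, `CSc1ccc(C)cc1NCC1=NCCN1`, gives 977 nM in an assay on CHO cells for binding affinity to Alpha-2B adrenergic receptor (Homo sapiens), read by radioligand binding; a lower number here means a stronger inhibitor, a higher number a weaker inhibitor
compound 2, `CS(=O)(=O)c1ccc(Cl)cc1NCC1=NCCN1`, gives < 6310 nM in this assay

Compound 2 stands on a limit only: in this assay compound 2 gives < 6310 nM, which is a limit of the assay and not a number (the limit of < 6310 nM in this assay, at which 1 of the 2 values shown sits). Going by the values given here, compound 1 is the one measured compound with a number, and it carries methylsulfanyl where compound 2 carries methylsulfonyl.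

Compound 3, `CSc1ccc(Cl)cc1NCC1=NCCN1`, is not yet measured. From compound 2 it differs by methylsulfanyl in place of methylsulfonyl on an aromatic carbon. Among the compounds with values here, no step between measured compounds is available, and as compound 2 sits on a limit the direction of the step cannot be read from the numbers. The step expected for a step that the limit leaves unreadable from compound 2 to compound 3 is toward the region where compound 1 sits. Compound 3 is expected to give 900 nM, with a range from 250 nM to 3500 nM.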

Compound 3, inhibition constant: 676 nM
The estimate for compound 3 lay 1.3-fold (0.12 log units) above the measured number, within the range that was stated.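

Chloro in place of methyl on an aromatic carbon, with methylsulfanyl kept, gives in this assay a 1.4-fold lower number from compound 1 to compound 3 (0.16 log units; within the scatter), so this change does not separate the two compounds. Compound 2 gives < 6310 nM in this assay, which is a limit of the assay and not a number. The step from compound 2 to compound 3 therefore cannot be read, and this pair gives no size for methylsulfanyl in place of methylsulfonyl, even though compound 3 now supplies a number on the chloro side of the pair: the limit of < 6310 nM in this assay, at which 1 of the 3 values shown sits.

On these data alone, the effect of methylsulfonyl at this position thus remains open. Also open, as far as these compounds go, is how a methoxy group, an amine or a longer chain such as ethylsulfanyl would compare with methylsulfanyl on this aromatic carbon, with the chloro group kept.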